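Shifting a chloro substituent on the anilino ring

This account rests on a few compounds, and the source may have more. Where it says the series, first, only, none or still open, it means among the compounds named here.

Compound 1 `COc1ccc(Nc2nc(-c3cccc(F)c3)nc3ccc(F)cc23)cc1` gives 42300 nM in a functional assay on HT29-AK cells (Homo sapiens) for cytotoxicity, read by MTT assay, with a stated time of 48 h (on this read-out lower numbers stand for stronger inhibition and higher numbers for weaker inhibition), the highest of the two numbers recorded there, though its nearest neighbour, compound 2 `Fc1cccc(-c2nc(Nc3ccc(Cl)cc3)c3cc(F)ccc3n2)c1` at 40300 nM, sits within the scatter of it. Compound 3 `Fc1cccc(-c2nc(Nc3ccccc3Cl)c3cc(F)ccc3n2)c1` differs from compound 1 by 2-chlorophenyl in place of 4-methoxyphenyl on a nitrogen on an aromatic ring. For the measured compounds named here, the only measured step that bears on this change is a 1.0-fold lower number from compound 1 to compound 2 (0.02 log units; within the scatter), and it covers only part of the change, since the chlorine in compound 3 sits at a different position of the ring. He therefore expects no step beyond the scatter, a 1.1-fold lower number from compound 1 to compound 3 (0.02 log units; within the scatter), and estimates compound 3 at 40000 nM, within 15000 nM to 110000 nM.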

Compound 3, half-maximal inhibitory concentration: > 50000 nM
Compound 3 was reported as a limit; the forecaster's own chance of this, stated with the estimate: 20%; middle value at least 1.2-fold (0.09 log units) from the limit.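

Compound 3 gives only a limit, not a number, in this assay: the limit of > 50000 nM in this assay, at which 1 of the 3 values shown sits.

Moving the chlorine, as 2-chlorophenyl in place of 4-chlorophenyl, gives an at least 1.2-fold higher number from compound 2 to compound 3 (0.09 log units; that floor lies within the scatter), and replacing 4-methoxyphenyl with 2-chlorophenyl gives an at least 1.1-fold higher number from compound 1 to compound 3 (0.07 log units; that floor lies within the scatter). Neither change brings a lower number at this position, although neither floor separates the compounds beyond the scatter.

On these data alone, how far compound 3 really lies from compound 1 and compound 2 stays open. So does whether an amine or a carboxylic acid on this ring would bring a lower number.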